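Cyclobutyl in place of a branched chain: solubility outlook

This account rests on a few compounds, and the source may have more. Where it says the series, first, only, none or still open, it means among the compounds named here.

Three compounds have been measured in a physicochemical assay for solubility; on this read-out higher numbers stand for higher solubility and lower numbers for lower solubility:
Compound 1, `O=C(N[C@@H](CO)C(=O)NO)c1ccc(C#Cc2ccccc2)cc1`, gives 28000 nM.
Compound 2, `NC[C@H](NC(=O)c1ccc(C#Cc2ccccc2)cc1)C(=O)NO`, gives 13000 nM.
Compound 3, `CC(C)C(NC(=O)c1ccc(C#Cc2ccccc2)cc1)C(=O)NO`, gives 7000 nM.

Compound 3 has the lowest of the three numbers; its gap to compound 2 is within the scatter, while the step from compound 1 reached beyond it: a 4.0-fold lower number from compound 1 to compound 3 (0.60 log units; beyond the scatter). The two steps that bear on the next change are both swaps of the group on the amide-type nitrogen, a 4.0-fold lower number from compound 1 to compound 3 (0.60 log units; beyond the scatter) and a 1.9-fold lower number from compound 2 to compound 3 (0.27 log units; within the scatter), each modest at most.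

Compound 4, `O=C(NC1(C(=O)NO)CCC1)c1ccc(C#Cc2ccccc2)cc1`, differs from compound 3 at that same position: 1-(hydroxycarbamoyl)cyclobutyl in place of 1-(hydroxycarbamoyl)-2-methylpropyl on an amide-type nitrogen. The group that leaves and the group that enters are alike in count of atoms, donors and acceptors, and differ only in the ring. Nothing measured shows how a four-membered ring at this position affects this assay. Compound 4 is therefore expected to sit close to compound 3, with a step of no change at the digits printed from compound 3 to compound 4 (within the scatter), within the scatter. Compound 4 is estimated at 7000 nM, in a range from 3000 nM to 16000 nM.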

Compound 4, solubility: 5000 nM
For compound 4 the middle estimate is 1.4-fold (0.15 log units) above the measured one; the range from low to high includes it.
By their numbers in this assay, from the lowest: compounds 4, 3 and 2 (each within the scatter of the next, the first and the last beyond it); then compound 1.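

In this assay, exchanging 1-(hydroxycarbamoyl)-2-methylpropyl for 1-(hydroxycarbamoyl)cyclobutyl on the amide-type nitrogen gives a 1.4-fold lower number from compound 3 to compound 4 (0.15 log units; within the scatter), so the four-membered ring, new at this position, cannot be told apart from the open branched group on this read-out. Compound 4 stays clearly apart from the two compounds with a hydroxy or amino group on the chain, with a 2.6-fold lower number from compound 2 to compound 4 (0.41 log units; beyond the scatter) and a 5.6-fold lower number from compound 1 to compound 4 (0.75 log units; beyond the scatter), both modest steps. No supporting measurement is available to explain these numbers.

The compounds shown leave open whether a five-membered ring of carbon only at this position would also stay within the scatter of compound 4. They also leave open what an amine or a hydroxy group carried on the four-membered ring would do in this assay.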